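The source may hold more compounds than are shown below. What is called first, only, known or untested is meant among the compounds shown, and "the series" means these compounds.

Series on the shared core of compound 1 `C=CCN(CCCC(=O)O)C(=O)/C(C)=C/c1ccc(C(=O)Oc2ccc(C(=N)N)cc2)cc1`. In an in vitro ADME assay on a cell-free system (plasma) for pharmacokinetics (a lower number here means that the compound disappears faster, a higher number that the compound lasts longer), compound 1 gives > 1 h, which is a limit of the method. Compound 3 `C/C(=C\c1ccc(C(=O)Oc2ccc(C(=N)N)cc2)cc1)C(=O)N(CC(=O)O)C1CCCCC1` gives > 1 h, likewise a limit. The step that the two limits leave unreadable from compound 1 to compound 3 therefore cannot be sized; both sit at the limit of > 1 h in this assay, at which 2 of the 3 values shown sit. Compound 2 `CCOC(=O)CCCN(C(=O)/C(C)=C/c1ccc(C(=O)Oc2ccc(C(=N)N)cc2)cc1)C(C(=O)OCC)C(=O)OCC` gives < 0.0167 h, also a limit, at the limit of < 0.0167 h in this assay, at which 1 of the 3 values shown sits. Compound 4 `CCOC(=O)C(C(=O)OCC)N(CCCC(=O)O)C(=O)/C(C)=C/c1ccc(C(=O)Oc2ccc(C(=N)N)cc2)cc1` differs from compound 2 by hydrogen in place of ethyl on an oxygen next to a carbonyl group. Going by the values given here, no measured step bears directly on this change, and the single step between measured compounds is unreadable. Compound 4 retains ethoxycarbonyl groups that compound 1 and compound 3 lack. Compound 4 is thus expected to stay nearer the short end, estimated at 0.1 h (range 0.017 h to 0.7 h), an expected step of an at least 5.9-fold higher number from compound 2 to compound 4 (0.77 log units; beyond the scatter).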

Compound 4, half-life: 0.483 h
Beside the measured number, compound 4's estimate is 4.8-fold (0.68 log units) below it; measured number inside the range.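

In this assay, hydrogen in place of ethyl on an oxygen next to a carbonyl group gives an at least 28-fold higher number from compound 2 to compound 4 (1.46 log units; beyond the scatter), so this one ester position moves the half-life off the short limit even though two ethoxycarbonyl groups remain. Bis(ethoxycarbonyl)methyl in place of allyl on an amide-type nitrogen gives an at least 2.0-fold lower number from compound 1 to compound 4 (0.31 log units; beyond the scatter), the first step from the long end of the series with a readable minimum size. Both steps start from a limit of the method and so give only minimum sizes.

Still open, as far as these compounds go, is whether a dicarboxymethyl group on the amide-type nitrogen would restore the longer half-life. Equally open, from the compounds shown here alone, is how a primary amide in place of the carboxy group would behave.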